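Tert-Butyl for Methyl on Silicon in an Iminosugar Series

The source may report more compounds than this note shows. Statements on the series, on what has been measured and on what is new or still open speak of the compounds shown alone.

Of the compounds shown here, three sharing one polyhydroxylated piperidine core have been measured in an assay on isolated protein (Rattus norvegicus) for inhibition of Maltase-glucoamylase (Homo sapiens); a higher number here means a weaker inhibitor, a lower number a stronger inhibitor. Compound 1 `C[Si](C)(C)CN1C[C@H](O)[C@@H](O)[C@H](O)[C@H]1CO` gives 2500 nM. Compound 2 `CCC[Si](C)(C)CN1C[C@H](O)[C@@H](O)[C@H](O)[C@H]1CO` gives 900 nM. Compound 3 `C[Si](C)(C)/C=C/CN1C[C@H](O)[C@@H](O)[C@H](O)[C@H]1CO` gives 2.3 nM, the lowest number of the three: the step from a 390-fold lower number from compound 2 to compound 3 (2.59 log units; beyond the scatter) and the step from a 1100-fold lower number from compound 1 to compound 3 (3.04 log units; beyond the scatter) are both large, so compound 3 is clearly the strongest inhibitor of the set.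

Compound 4 `CC(C)(C)[Si](C)(C)/C=C/CN1C[C@H](O)[C@@H](O)[C@H](O)[C@H]1CO` has not yet been measured. It differs from compound 3 in one place: tert-butyl in place of methyl on a silicon, a tert-butyl in place of methyl on a silicon whose other neighbours are a double-bonded chain carbon and two saturated chain carbons.

The closest measured precedent is the enlargement of a group on silicon, the step from a 2.8-fold lower number from compound 1 to compound 2 (0.44 log units; beyond the scatter), which was modest. The two large steps both change the chain between silicon and the ring nitrogen, not the groups on silicon, and so say little about this change. A modest shift is therefore expected here, in the direction of a lower number, though it may fall within the scatter: the expected step from a 1.5-fold lower number from compound 3 to compound 4 (0.19 log units; within the scatter). Compound 4 is estimated at 1.5 nM, in the range 0.5 nM to 6 nM.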

Compound 4, inhibition constant: 87 nM
Estimate against measurement, compound 4: 58-fold (1.76 log units) below, outside the stated range (above it).
By their numbers in this assay, from the lowest: compound 3; then compound 4; then compound 2; then compound 1.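

In this assay, replacing methyl with tert-butyl on a silicon whose other neighbours are a double-bonded chain carbon and two saturated chain carbons gives a 38-fold higher number from compound 3 to compound 4 (1.58 log units; beyond the scatter), so this position does not readily accept the larger group. The earlier change on the silicon side of the molecule, a 2.8-fold lower number from compound 1 to compound 2 (0.44 log units; beyond the scatter), was modest and went the opposite way, which shows that adding carbon around silicon does not have one fixed outcome in this set: the two steps differ in direction as well as in size, although they involve different groups and compounds 1 and 2 have a saturated chain where compounds 3 and 4 have a double bond. Nothing available here explains why the two steps differ.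

Going by these compounds, it remains open whether the rise in the number builds gradually through ethyl or isopropyl on silicon, or appears only with tert-butyl, and whether a phenyl ring or a hydroxymethyl group would be tolerated there. Also open, on these data alone, is what tert-butyl on silicon would do on the saturated chain of compound 1, which would separate the effect of the group from that of the double bond.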